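Methoxy in Place of Fluoro: Estimating Compound 4

The source may report more compounds than this note shows. Statements on the series, on what has been measured and on what is new or still open speak of the compounds shown alone.

Measured so far in an assay on isolated protein for inhibition of alpha-mannosidase (Canavalia ensiformis), tested at 1000 uM; on this read-out lower numbers stand for less inhibition and higher numbers for more inhibition at the one concentration tested (going by the name of the read-out):
compound 1, `OC[C@]1(c2cccc(F)c2)NC[C@H](O)[C@H]1O`, gives 0%.
compound 2, `OC[C@@]1(c2cccc(F)c2)NC[C@@H](O)[C@@H]1O`, gives 0%.
compound 3, `OC[C@]1(c2c(F)c(F)c(F)c(F)c2F)NC[C@H](O)[C@H]1O`, gives 6.6%.

Compound 2 stands level with compound 1, the two together the lowest of the three numbers in this assay; compound 3 lies higher by an amount within the scatter. Among the compounds with values here, the only measured step is no change at the digits printed from compound 1 to compound 2 (within the scatter), and it shows no change, which fits (the fact that compounds 1 and 2 differ only in the configuration as drawn). Compound 4, `COc1cccc([C@]2(CO)NC[C@@H](O)[C@@H]2O)c1`, differs from compound 2 by methoxy in place of fluoro on an aromatic carbon. No measured step exchanges one group for another on the aromatic ring, so nothing shown supports a move beyond the scatter. Compound 4 is therefore expected to give 2%, between 0% and 12%. The expected step is a number 2 percentage points higher from compound 2 to compound 4 (within the scatter).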

Compound 4, a percentage reported as inhibition, at one concentration (the size of the read-out at that concentration, not a potency): 0%
Compound 4: middle estimate off by 2 percentage points, on the high side; low and high end bracket the measured number.
By their numbers in this assay, from the lowest: compounds 1, 2, 4 and 3 (each within the scatter of the next).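

At this position on the aromatic ring, methoxy in place of fluoro brings no change at the digits printed from compound 2 to compound 4 (within the scatter) in this assay. The entering group carries a hydrogen-bond acceptor that fluoro lacks, yet the read-out does not move, so this exchange of one group for another leaves the number where it was. Nothing known about these compounds bears on why this step reads as it does.

The compounds shown leave open whether an amine or a carboxylic acid at this place would move the number. They also leave open whether methoxy would read the same on the mirror-image configuration of compound 1.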